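Swapping fluoro for trifluoromethyl on the alkyne-linked ring

A few compounds are considered here, and "the series" means these few. Any claim that something is new, unique, unknown or untested is made for them only; others in the source may bear on it.

Measured compounds:
- compound 1, `O=C(CCCCC#Cc1cccnc1)c1ncc(-c2ccccn2)o1`: 300 nM
- compound 2, `O=C(CCCCC#Cc1cccc(F)c1)c1ncc(-c2ccccn2)o1`: 3.2 nM

In an assay for inhibition of Fatty-acid amide hydrolase 1 (Rattus norvegicus) (on this read-out higher numbers stand for weaker inhibition and lower numbers for stronger inhibition), compound 2 gives the lowest of the two numbers shown; the nearest is compound 1, and the move from compound 1 to compound 2 was a 94-fold lower number from compound 1 to compound 2 (1.97 log units; beyond the scatter), a large drop from a change of the aromatic ring on the triple-bonded carbon. Compound 3, `O=C(CCCCC#Cc1cccc(C(F)(F)F)c1)c1ncc(-c2ccccn2)o1`, keeps that 3-fluorophenyl ring but alters its substituent: trifluoromethyl in place of fluoro on an aromatic carbon. Within the data shown here, no measured step changes a substituent on this ring while leaving the ring itself in place, so the only step that touches the same part of the molecule is the ring swap from compound 1 to compound 2, and that step does not tell what a trifluoromethyl group would do. For compound 3 a change in this assay of a 1.3-fold higher number from compound 2 to compound 3 (0.10 log units; within the scatter) is expected, within or only slightly beyond the scatter. The estimate for compound 3 is 4 nM, with a range from 1.2 nM to 15 nM.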

Compound 3, inhibition constant: 10 nM
For compound 3 the middle estimate is 2.5-fold (0.40 log units) below the measured one, and the stated range covers the measured number.
By their numbers in this assay, from the lowest: compound 2; then compound 3; then compound 1.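

In this assay, the step of a 3.1-fold higher number from compound 2 to compound 3 (0.49 log units; beyond the scatter) is the only one shown that changes a substituent while leaving this ring in place, and it shows that inhibition depends on which group sits at this position. This change of fluoro, one heavy atom, to trifluoromethyl, four heavy atoms, has a much smaller effect than the ring change, a 94-fold lower number from compound 1 to compound 2 (1.97 log units; beyond the scatter), though it still lies beyond the usual scatter. No measurement available here explains why the number rises with this change.

Two substituents on this ring cannot establish a trend with group size. On these data alone, it remains open how a chlorine atom, a methoxy group or a nitrile at the same position would compare with fluoro and trifluoromethyl.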